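The source may report more compounds than this note shows. Statements on the series, on what has been measured and on what is new or still open speak of the compounds shown alone.

Compound 1 `O=C(NCCCCc1ccccc1)c1ccc[nH]1` and compound 2 `CN(CCCCc1ccccc1)C(=O)c1ccc[nH]1` share a core and differ only by methyl in place of hydrogen on an amide-type nitrogen. In an assay on mitochondria for inhibition of Amine oxidase [flavin-containing] A (Bos taurus), read by fluorescence (a lower number here means a stronger inhibitor, a higher number a weaker inhibitor), compound 1 gives 55 nM, and compound 2 gives 90 nM, so the step of a 1.6-fold higher number from compound 1 to compound 2 (0.21 log units; within the scatter). Compound 3 `CC(NC(=O)c1ccc[nH]1)c1ccccc1` carries a different core; the difference between the two cores is not broken down here. In this assay compound 3 gives 1220 nM, the highest of the three numbers. Compound 4 `CC(c1ccccc1)N(C)C(=O)c1ccc[nH]1` is related to compound 3 by methyl in place of hydrogen on an amide-type nitrogen, the same change as that from compound 1 to compound 2. Because the earlier step of a 1.6-fold higher number from compound 1 to compound 2 (0.21 log units; within the scatter), the same small movement is expected here. In this assay compound 4 is expected to give 1800 nM, likely between 900 nM and 4000 nM, which means an expected step of a 1.5-fold higher number from compound 3 to compound 4 (0.17 log units; within the scatter).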

Compound 4, inhibition constant: 10 nM
Compound 4: the middle estimate sits 180-fold (2.26 log units) above what was measured; the whole stated range lies above it.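

In this assay, methyl in place of hydrogen on an amide-type nitrogen gives a 120-fold lower number from compound 3 to compound 4 (2.09 log units; beyond the scatter). The same change therefore does not carry over unchanged between these two cores, and its size depends on the core that bears it: the same change on two cores in this assay, a 1.6-fold higher number (0.21 log units; within the scatter) from compound 1 to compound 2 and a 120-fold lower number (2.09 log units; beyond the scatter) from compound 3 to compound 4, 200-fold (2.30 log units) apart, beyond the scatter of two such steps. For the compounds shown here, this rests on only two pairs of compounds, and it does not show why the two cores differ or how the change would behave on any other core.

The compounds shown leave open whether ethyl or a longer chain on that nitrogen, in place of methyl, would keep the number for compound 4 as low. They also leave open whether the same change on a further core would produce a small step or a large one.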